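The source may report more compounds than this note shows. Statements on the series, on what has been measured and on what is new or still open speak of the compounds shown alone.

Measured so far:
compound 1 `CN(C)CCN1CCN(CC(=O)Nc2ccc(-c3nc4cc(F)ccc4o3)cc2)CC1`, 20800 nM
compound 2 `Cc1ccc2oc(-c3ccc(NC(=O)CN4CCN(CCCN(C)C)CC4)c(C)c3)nc2c1`, 19800 nM

Both were tested in a functional assay on MCF7 cells (Homo sapiens) for cytotoxicity, read by MTT assay, with a stated time of 24 h; a lower number here means a stronger inhibitor, a higher number a weaker inhibitor. Compound 1 gives 20800 nM; compound 2 gives 19800 nM, and the two numbers lie within the usual scatter of each other, so they cannot be told apart. Compound 3 `CN(C)CCN1CCN(CC(=O)Nc2ccc(-c3nc4ccccc4o3)cc2)CC1` has not yet been measured. It differs from compound 1 by hydrogen in place of fluoro on an aromatic carbon. Going by the values given here, no measured pair shows this change, so the step is expected to be small, none beyond the scatter, in either direction. The step expected here is a 1.0-fold higher number from compound 1 to compound 3 (0.00 log units; within the scatter). Compound 3 is therefore estimated at 21000 nM, with a range from 8000 nM to 55000 nM.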

Compound 3, half-maximal inhibitory concentration: 59400 nM
For compound 3 the middle estimate is 2.8-fold (0.45 log units) below the measured one; measured number above the stated range.
By their numbers in this assay, from the lowest: compounds 2 and 1 (each within the scatter of the next); then compound 3.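

In this assay the change from 5-fluoro-1,3-benzoxazol-2-yl to 1,3-benzoxazol-2-yl gives a 2.9-fold higher number from compound 1 to compound 3 (0.46 log units; beyond the scatter) and so reaches beyond the scatter. This aromatic carbon is therefore not indifferent to what it carries: with all else unchanged, the fluoro compound is the stronger inhibitor of this pair, though only modestly. Nothing shown gives a reason for this step.

As far as these compounds go, whether chloro, methoxy or an amine at this place would match fluoro or hydrogen stays open. So does whether the same swap gives a similar step with a different side chain.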